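Swapping a Methyl for Fluorine on the Benzyl Arm

This account rests on a few compounds, and the source may have more. Where it says the series, first, only, none or still open, it means among the compounds named here.

Measured compounds:
compound 1, `Cc1ccc(CNC(=O)c2nc(-c3ccc(F)cc3)n(CC[C@@H](O)C[C@@H](O)CC(=O)O)c2C2CC2)cc1`: 1.7 nM
compound 2, `CC(C)c1c(C(=O)NCc2ccccc2)nc(-c2ccc(F)cc2)n1CC[C@@H](O)C[C@@H](O)CC(=O)O`: 7.9 nM

Both compounds were tested in an assay on microsomes from liver for inhibition of 3-hydroxy-3-methylglutaryl-coenzyme A reductase (Rattus norvegicus), read by scintillation counting, with stated times of 0.5 h and 0.75 h; a lower number here means a stronger inhibitor, a higher number a weaker inhibitor. Compound 1 gives 1.7 nM, the lowest of the two numbers. Compound 2 gives 7.9 nM, a higher number, and the gap between the two lies beyond the usual scatter of the assay. Compound 2 differs from compound 1 in more than one place, so the pair only shows that another variant of the shared core comes out as a noticeably weaker inhibitor; it does not isolate any single change.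

Compound 3, `O=C(O)C[C@H](O)C[C@H](O)CCn1c(-c2ccc(F)cc2)nc(C(=O)NCc2ccccc2F)c1C1CC1`, has not yet been measured. It differs from compound 1 in one place: 2-fluorophenyl in place of 4-methylphenyl on a saturated chain carbon bound to an amide-type nitrogen. Among the measured compounds shown here, no measured pair shows this exact change, so the expectation rests on compound 1 alone. The aromatic ring is kept and only its substituent is exchanged, so the step of a 1.8-fold higher number from compound 1 to compound 3 (0.25 log units; within the scatter) is expected to be small, toward a higher number, and probably within the scatter. Compound 3 is therefore estimated at 3 nM, with a range from 1.2 nM to 8 nM.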

Compound 3, half-maximal inhibitory concentration: 1.5 nM
For compound 3 the middle estimate is 2.0-fold (0.30 log units) above the measured one; low and high end bracket the measured number.
By their numbers in this assay, from the lowest: compounds 3 and 1 (each within the scatter of the next); then compound 2.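

In this assay the exchange of 4-methylphenyl for 2-fluorophenyl on a saturated chain carbon bound to an amide-type nitrogen gives a small step (a 1.1-fold lower number from compound 1 to compound 3 (0.05 log units; within the scatter)), so the assay does not tell these two compounds apart. Among the compounds shown here, this is the first pair here that differs in one place only, and it shows that this arm of the shared core can carry either a 4-methylbenzyl or a 2-fluorobenzyl group with no change in the number beyond the usual scatter. Nothing at hand explains why the two groups read alike.

From the compounds shown here alone, the step alters both the kind of substituent on the ring and where it sits, so it remains open how each of these two differences would read alone. Also open, going by these compounds, is whether the arm would tolerate a much larger departure, such as an amine or a carboxylic acid on the ring, or a longer chain between the amide nitrogen and the ring.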